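A few compounds are considered here, and "the series" means these few. Any claim that something is new, unique, unknown or untested is made for them only; others in the source may bear on it.

Measured compounds:
compound 1, `COc1cc(C)cc(-c2nn(CC#N)cc2-c2ccc(-c3cccc(C(C)=O)c3)nc2)c1`, > 100000 nM in a functional assay on SR cells (Homo sapiens) for inhibition, read by sulforhodamine B assay, with a stated time of 48 h; a higher number here means a weaker inhibitor of growth, a lower number a stronger inhibitor of growth
compound 2, `Cc1cc(O)cc(-c2nn(CC#N)cc2-c2ccnc(-c3ccc(Oc4ccccc4)cc3)c2)c1`, 37200 nM in this assay

Of the compounds shown here, two have been measured. For compound 1 the result in this assay is a limit of the assay, not a number; this is the same point described by the limit of > 100000 nM in this assay, at which 1 of the 2 values shown sits. Compound 2 therefore stands as the only compound with a number shown in this assay, and that number marks a weak inhibitor of growth.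

The step under consideration leads from compound 2 to compound 3, whose structure is `Cc1cc(O)cc(-c2nn(CC#N)cc2-c2ccnc(-c3ccc(N(C)C)cc3)c2)c1`. The change is dimethylamino in place of phenoxy on an aromatic carbon, the place being para to a large group. No step between measured compounds gives a guide to what such a swap does in this assay, so the expectation rests on the one number shown for compound 2 alone. The step is expected to be small in this assay, in no firm direction, and most likely not beyond the scatter of repeated measurements. Compound 3 is thus estimated at 40000 nM, within the range 10000 nM to 150000 nM, which means an expected step of a 1.1-fold higher number from compound 2 to compound 3 (0.03 log units; within the scatter).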

Compound 3, concentration for total growth inhibition: > 100000 nM
Compound 3: only a limit was reported (the forecaster's own chance of this, stated with the estimate: 30%); middle value at least 2.5-fold (0.39 log units) away from the limit.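

In this assay, the position para to a large group is not indifferent to this swap: dimethylamino in place of phenoxy on an aromatic carbon gives an at least 2.6-fold higher number from compound 2 to compound 3 (0.42 log units; beyond the scatter). In this assay, compound 3 gives > 100000 nM, which is a limit of the assay and not a number. The step therefore has a lower bound but no measured size, and the only numerical value shown, that of compound 2, is lost when phenoxy leaves, so that the values resting at the limit now form the majority: the limit of > 100000 nM in this assay, at which 2 of the 3 values shown sit.

The change removes the six-membered aromatic ring of carbon only and also replaces oxygen with nitrogen at the point of attachment, and these compounds cannot separate what each of those differences contributes to the step. Going by these compounds, a methoxy group would keep the oxygen without the ring and an anilino group would keep the ring with a nitrogen at that point, so either at this place could begin to separate them, while the true size of the step remains open.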